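The source may report more compounds than this note shows. Statements on the series, on what has been measured and on what is new or still open speak of the compounds shown alone.

Measured in a functional assay on MDA-MB-231 cells (Homo sapiens) for inhibition, read by MTT assay; a higher number here means a weaker inhibitor of growth, a lower number a stronger inhibitor of growth:
- compound 1 `CC1=C(/C=C/C(C)=C/C=C/C(C)=C\C(=O)Nc2ccccc2)C(C)(C)CCC1n1ccnc1`: 1740 nM
- compound 2 `CC1=C(/C=C/C(C)=C/C=C/C(C)=C\C(=O)Nc2cccc(F)c2)C(C)(C)CCC1n1ccnc1`: 8510 nM
- compound 3 `CC1=C(/C=C/C(C)=C/C=C/C(C)=C\C(=O)Nc2ccccc2)C(C)(C)CC=C1c1cncnc1`: 26900 nM

Compound 2, at 8510 nM, holds the middle of the three numbers, with compound 1 lower and compound 3 higher. Compound 4 `CC1=C(/C=C/C(C)=C/C=C/C(C)=C\C(=O)NCc2ccc(F)cc2)C(C)(C)CCC1n1ccnc1` carries 4-fluorobenzyl in place of 3-fluorophenyl on an amide-type nitrogen. Among the compounds with values here, the only measured step that bears on this change is a 4.9-fold higher number from compound 1 to compound 2 (0.69 log units; beyond the scatter), a modest step for fluoro in place of hydrogen on an aromatic carbon. It covers only part of the change. Within the data shown here, no measured compound has a benzyl group on that nitrogen, and compound 3 has no one-place step to compound 2. The direction is therefore poorly fixed. A slight lean towards a lower number rests on compound 1 at 1740 nM. No step beyond the scatter is expected, and the expected step is a 1.7-fold lower number from compound 2 to compound 4 (0.23 log units; within the scatter). For compound 4 the estimated value is 5000 nM, with an expected range of 1500 nM to 17000 nM.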

Compound 4, concentration for 50% growth inhibition: 1410 nM
Compound 4: middle estimate off by 3.5-fold (0.55 log units), on the high side; measured number outside the range, below it.
By their numbers in this assay, from the lowest: compounds 4 and 1 (each within the scatter of the next); then compound 2; then compound 3.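

In this assay, the amide-type nitrogen accepts 4-fluorobenzyl without the loss seen with 3-fluorophenyl: the change gives a 6.0-fold lower number from compound 2 to compound 4 (0.78 log units; beyond the scatter), while the comparison with the plain phenyl gives a 1.2-fold lower number from compound 1 to compound 4 (0.09 log units; within the scatter). Fluorine in the group on this nitrogen therefore does not always go with a higher number, although this step alters the fluoro position and replaces phenyl with benzyl at once, so the two changes cannot be separated. Nothing on hand explains the difference between these groups.

Open, as far as these compounds go, is how unsubstituted benzyl and 3-fluorobenzyl on this nitrogen would compare with compound 4, which would separate the effect of the benzyl group from that of the fluoro position. Also open, from the compounds shown here alone, is whether a longer chain, such as 2-phenylethyl, or a carboxylic acid on the aromatic ring would hold the number near that of compound 4.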